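The source may hold more compounds than are shown below. What is called first, only, known or untested is meant among the compounds shown, and "the series" means these compounds.

Measured so far in an ADME assay on cells (Homo sapiens) for cytotoxicity, read by polymerase chain reaction, with a stated time of 3 days; a higher number here means that more compound is tolerated, a lower number that less compound is tolerated:
- compound 1, `CNc1ccc2nc(-c3c(Cl)nc(N)nc3N[C@@H]3C[C@H](CO)[C@@H](O)[C@H]3O)sc2c1`: 6000 nM
- compound 2, `CN(C)c1ccc2nc(-c3c(Cl)nc(N)nc3N[C@@H]3C[C@H](CO)[C@@H](O)[C@H]3O)sc2c1`: > 25000 nM
- compound 3, `COCCNc1nc(C)c(-c2nc3ccccc3s2)c(N[C@@H]2C[C@H](CO)[C@@H](O)[C@H]2O)n1`: 21000 nM

Compound 2 gives only a limit in this assay, not a number; it sits at the limit of > 25000 nM in this assay, at which 1 of the 3 values shown sits. Among the two numbers actually read, compound 3 stands highest: compound 1 is the nearest, and the gap between them is beyond the scatter. Among the compounds with values here, the one step between measured neighbours, an at least 4.1-fold higher number from compound 1 to compound 2 (0.61 log units; beyond the scatter), concerns methyl in place of hydrogen on a nitrogen on an aromatic ring and is at least modest in size.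

Compound 4 is `Cc1nc(NCc2ccsc2)nc(N[C@@H]2C[C@H](CO)[C@@H](O)[C@H]2O)c1-c1nc2ccccc2s1`. It differs from compound 3 as follows: thiophen-3-yl in place of methoxymethyl on a saturated chain carbon bound to a nitrogen on an aromatic ring. Within the data shown here, no measured pair here shares this change; the step from compound 1 to compound 2 alters a ring nitrogen substituent on a different part of the scaffold and gives no direct guide to swapping methoxymethyl for thiophen-3-yl on the chain carbon. With only compound 3 as anchor and nothing that bears on the change, the step of a 1.4-fold lower number from compound 3 to compound 4 (0.15 log units; within the scatter) is expected to stay within the scatter, in no preferred direction. Compound 4 is therefore estimated at 15000 nM, with a range from 5000 nM to 40000 nM in this assay.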

Compound 4, half-maximal cytotoxic concentration: 6000 nM
For compound 4 the middle estimate is 2.5-fold (0.40 log units) above the measured one; measured number inside the range.
By their numbers in this assay, from the lowest: compounds 1 and 4 (each within the scatter of the next); then compound 3. At a limit, above all of these: compound 2.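

In this assay, within the data shown here, thiophen-3-yl in place of methoxymethyl on a saturated chain carbon bound to a nitrogen on an aromatic ring gives a 3.5-fold lower number from compound 3 to compound 4 (0.54 log units; beyond the scatter) and this modest step is the first reading at this position. The position therefore bears on how much compound is tolerated, and it joins the nitrogen substituent on the other part of the scaffold, where the step reads an at least 4.1-fold higher number from compound 1 to compound 2 (0.61 log units; beyond the scatter) as a second place where a single change moves the number beyond the scatter. The direction rests on this one pair and sets no trend, and nothing measured here accounts for the step.

Going by these compounds, the pair changes the ring, the sulfur and the size of the group together, so it remains open which of these goes with the lower number. Also open, on these data alone, is how a phenyl ring, a plain butyl chain or a terminal amine on the same chain would read against compound 3 and compound 4 in this assay and whether any of them would keep the number of the methoxy chain.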